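Ethyl to propyl on a sulfonate ester urea series

This account rests on a few compounds, and the source may have more. Where it says the series, first, only, none or still open, it means among the compounds named here.

Measured so far:
Compound 1, `Cc1ccccc1OS(=O)(=O)c1ccc(NC(=O)NCCCCl)cc1`, 26000 nM
Compound 2, `CCc1ccccc1OS(=O)(=O)c1ccc(NC(=O)NCCCCl)cc1`, 15000 nM
Compound 3, `CCNC(=O)Nc1cccc(S(=O)(=O)Oc2ccccc2CC)c1`, 33000 nM

In a functional assay on HT-29 cells (Homo sapiens) for cytotoxicity, read by sulforhodamine B assay, with a stated time of 48 h (a lower number here means a stronger inhibitor, a higher number a weaker inhibitor), compound 1 gives 26000 nM. Compound 2 differs from compound 1 by methyl in place of hydrogen on a saturated chain carbon bound to an aromatic carbon, and this gave a 1.7-fold lower number from compound 1 to compound 2 (0.24 log units; within the scatter). Compound 3 rests on a different core; how its core differs from that of compound 1 is not broken down here. Compound 4, `CCCc1ccccc1OS(=O)(=O)c1cccc(NC(=O)NCC)c1`, has not yet been measured; it differs from compound 3 by methyl in place of hydrogen on a saturated chain carbon, two bonds along the chain from an aromatic carbon. This is the same kind of change as that from compound 1 to compound 2, though not the same: here the new methyl sits two bonds along the chain from an aromatic carbon, not bound to an aromatic carbon. Given that earlier step, compound 4 is expected to show a 1.7-fold lower number from compound 3 to compound 4 (0.22 log units; within the scatter), an estimate of 20000 nM, between 8000 nM and 50000 nM.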

Compound 4, half-maximal inhibitory concentration: 25000 nM
Beside the measured number, compound 4's estimate is 1.3-fold (0.10 log units) below it; the measured number falls inside the stated range.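

Lengthening the ethyl group to propyl gives a 1.3-fold lower number from compound 3 to compound 4 (0.12 log units; within the scatter) in this assay. Set beside the earlier methyl to ethyl step, the result is much the same on both cores: the same change on two cores in this assay, a 1.7-fold lower number (0.24 log units; within the scatter) from compound 1 to compound 2 and a 1.3-fold lower number (0.12 log units; within the scatter) from compound 3 to compound 4, 1.3-fold (0.12 log units) apart, within the scatter of two such steps. This shows that adding the methyl behaves alike on these two cores, but neither step stands clear of the scatter, so it does not show that the change truly alters the number, and two pairs make no rule for the whole series.

The compounds shown leave open whether a longer chain such as butyl, or an amine or a carboxylic acid in its place, would give a step beyond the scatter. They also leave open how propyl behaves on the core of compound 1.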